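Removing a Methyl Near a Benzylic Amine: Cytotoxicity Outlook

The source may hold more compounds than are shown below. What is called first, only, known or untested is meant among the compounds shown, and "the series" means these compounds.

Compound 1, `COc1ccc(Cn2c(C(=O)NCc3ccccc3)cc3sccc32)cc1`, gives > 100000 nM in an ADME assay on HEK-293T cells (Homo sapiens) for cytotoxicity, read by luminescence, with a stated time of 24 h (a higher number here means that more compound is tolerated, a lower number that less compound is tolerated), which is a limit of the assay.
Compound 2, `COc1ccc(Cn2c(C(=O)NC(C)c3ccccc3)cc3sccc32)cc1`, gives > 100000 nM in this assay, also a limit of the assay.
Compound 3, `CCCNC(=O)C1CCN(C(=O)c2cc3sc(CNC(C)c4ccccc4)cc3n2Cc2ccc(OC)cc2)CC1`, gives 33900 nM in this assay.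

Compound 1 differs from compound 2 by hydrogen in place of methyl on a saturated chain carbon bound to an amide-type nitrogen and an aromatic carbon. Because both of these values sit at the limit of > 100000 nM in this assay, at which 2 of the 3 values shown sit, the step that the two limits leave unreadable from compound 2 to compound 1 carries no readable size. The difference between the core of compound 3 and the core of compound 2 is not broken down here.

Compound 4, `CCCNC(=O)C1CCN(C(=O)c2cc3sc(CNCc4ccccc4)cc3n2Cc2ccc(OC)cc2)CC1`, has not yet been measured. It differs from compound 3 by hydrogen in place of methyl on a saturated chain carbon bound to an amine nitrogen and an aromatic carbon. For the measured compounds named here, this is the same kind of change as the one from compound 2 to compound 1, but the place is not the same: there the saturated chain carbon is bound to an amide-type nitrogen, here to an amine nitrogen. The expectation rests on compound 3 and its value 33900 nM, since the earlier step gives no size. For compound 4 a step of a 1.2-fold higher number from compound 3 to compound 4 (0.07 log units; within the scatter) within the usual scatter is expected. Compound 4 is therefore expected to give about 40000 nM, between 15000 nM and 100000 nM.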

Compound 4, half-maximal cytotoxic concentration: 46800 nM
Compound 4: middle estimate off by 1.2-fold (0.07 log units), on the low side, and the stated range covers the measured number.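

Replacing methyl with hydrogen on a saturated chain carbon bound to an amine nitrogen and an aromatic carbon gives a 1.4-fold higher number from compound 3 to compound 4 (0.14 log units; within the scatter) in this assay, so on this core the change cannot be told apart from the usual scatter of repeated measurements. The same kind of change on the core of compound 1, where the carbon is bound to an amide-type nitrogen, cannot be read, because both compounds of that pair sit at a limit of the assay: the limit of > 100000 nM in this assay, at which 2 of the 4 values shown sit. The series therefore offers one readable step on one core, which shows neither that the change carries over from one core to the other nor that it behaves differently between them.

The compounds shown leave open what a longer chain, such as ethyl, would do on that same carbon in place of methyl. Also open, on these data alone, is how an amide in place of the amine would read on the core of compound 4, with everything else kept the same.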